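Extending the Chain on Compound 2

The source may hold more compounds than are shown below. What is called first, only, known or untested is meant among the compounds shown, and "the series" means these compounds.

Going by the values given here, compound 2 `CCCCC(c1ccccc1)n1ccc2cc(/C(C)=C/C(=O)Nc3ccccc3OCCCC(=O)O)ccc21` gives 9.8 nM in an assay on Prostate gland for inhibition of steroid 5-alpha-reductase (Rattus norvegicus) (on this read-out higher numbers stand for weaker inhibition and lower numbers for stronger inhibition), the lowest of the two numbers measured so far; compound 1 `C/C(=C\C(=O)Nc1ccccc1OCCCC(=O)O)c1ccc2c(ccn2C)c1` gives 780 nM, and the step of an 80-fold lower number from compound 1 to compound 2 (1.90 log units; beyond the scatter) is large. Compound 3 `CCCCCC(c1ccccc1)n1ccc2cc(/C(C)=C/C(=O)Nc3ccccc3OCCCC(=O)O)ccc21` differs from compound 2 by methyl in place of hydrogen on a saturated chain carbon, five bonds along the chain from an aromatic carbon and an aromatic nitrogen. Among the compounds with values here, the one measured step concerns a different change, the group on the aromatic nitrogen, so no direct guide exists for lengthening the chain by a methyl. Compound 3 is expected to give about 9 nM (range 4 nM to 22 nM), an estimated step of a 1.1-fold lower number from compound 2 to compound 3 (0.04 log units; within the scatter) that stays within the scatter.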

Compound 3, half-maximal inhibitory concentration: 25 nM
Beside the measured number, compound 3's estimate is 2.8-fold (0.44 log units) below it; the measured number lies above the stated range.
By their numbers in this assay, from the lowest: compound 2; then compound 3; then compound 1.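

In this assay, methyl in place of hydrogen on this saturated chain carbon is not a neutral change: it brings a 2.6-fold higher number from compound 2 to compound 3 (0.41 log units; beyond the scatter) and shows that the 1-phenylpentyl group is the better of the two chains. Most of the gain over methyl on the aromatic nitrogen remains, with a 31-fold lower number from compound 1 to compound 3 (1.49 log units; beyond the scatter) still large. Nothing measured here accounts for the loss from the added methyl.

The compounds shown leave open whether a shorter chain such as propyl would match compound 2, whether a longer chain such as heptyl would continue the rise, and how an amine at the chain end would fare.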